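Replacing phenyl with 1H-pyrazol-5-yl in compound 3

The source may report more compounds than this note shows. Statements on the series, on what has been measured and on what is new or still open speak of the compounds shown alone.

In a functional assay on A-375 cells (Homo sapiens) for activation, with a stated time of 3 days (on this read-out higher numbers stand for an effect only at larger amounts of compound and lower numbers for an effect already at smaller amounts), compound 3 (`O=C(Nc1ccc(-c2ccccc2)cc1)C1CCCN(Cc2ccc(F)c(F)c2)C1`) gives 5000 nM. Compound 1 (`O=C(Nc1ccc(-c2cscn2)cc1)C1CCCN(Cc2ccc(F)cc2)C1`) gives 5000 nM, so the two stand level at the digits shown. Compound 2 (`O=C(Nc1ccc(-c2cscn2)cc1)C1CCCN(Cc2ccc3cn[nH]c3c2)C1`) gives > 20000 nM, and this is a limit of the assay, not a number.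

Compound 4 (`O=C(Nc1ccc(-c2ccn[nH]2)cc1)C1CCCN(Cc2ccc(F)c(F)c2)C1`) differs from compound 3 by one change on an aromatic carbon: 1H-pyrazol-5-yl in place of phenyl on an aromatic carbon.

Going by the values given here, the only measured step is an at least 4.0-fold higher number from compound 1 to compound 2 (0.60 log units; beyond the scatter). It is beyond the scatter and points to a higher number, but it was made at a different place in the molecule, so it bears on the new change only indirectly. Among the compounds with values here, no measured step covers the group that changes here. The working expectation in this assay is therefore no step beyond the scatter, with a slight lean towards a higher number. That lean rests only on compound 2 and its limit of > 20000 nM. The expected step is a 1.3-fold higher number from compound 3 to compound 4 (0.11 log units; within the scatter). The estimate for compound 4 is 6500 nM, with an expected range of 2500 nM to 18000 nM.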

Compound 4, half-maximal effective concentration: 580 nM
Compound 4: middle estimate off by 11-fold (1.05 log units), on the high side; the measured number lies below the stated range.
By their numbers in this assay, from the lowest: compound 4; then compounds 1 and 3 (each within the scatter of the next). At a limit, above all of these: compound 2.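

The aromatic carbon para to a large group now proves sensitive to its substituent: in this assay, 1H-pyrazol-5-yl in place of phenyl gives an 8.6-fold lower number from compound 3 to compound 4 (0.94 log units; beyond the scatter). Going by these compounds alone, this is the first measured step at this position, and it runs towards a lower number, whereas the only earlier step ran towards a higher number at a different place in the molecule. The entering ring is five-membered and carries 2 nitrogen atoms, with 1 hydrogen-bond donor and 1 hydrogen-bond acceptor where phenyl has none, but no measurement shown here bears on why the step occurs.

Which of these differences matters remains open, and a pyridine ring or a pyrazole with a methyl group on its ring nitrogen at this position would help to separate the hydrogen-bond donor from the ring nitrogens as such. Also open, going by these compounds, is whether the step carries over when the group on the saturated ring nitrogen is that of compound 1 rather than that of compound 3.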